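The compounds below may be only part of what the source reports. "The series", "measured", "known", "first", "only" and "open" are said of these compounds alone.

Measured in an assay on isolated protein for inhibition of Indoleamine 2,3-dioxygenase 1 (Homo sapiens), read by spectrophotometry; on this read-out higher numbers stand for weaker inhibition and lower numbers for stronger inhibition:
compound 1 `O=C(Cc1cccnc1)c1cc2cc(-c3ccccc3)ccc2[nH]1` gives 96000 nM
compound 2 `O=C(Cc1cccnc1)c1cc2ccccc2[nH]1` gives 65000 nM
compound 3 `O=C(Cc1cccnc1)c1cc2cc(O)ccc2[nH]1` gives 37000 nM

Compound 2 sits in the middle of the three numbers; the steps to its neighbours are a 1.5-fold lower number from compound 1 to compound 2 (0.17 log units; within the scatter) and a 1.8-fold lower number from compound 2 to compound 3 (0.24 log units; within the scatter), both within the scatter, so no order among compounds 1, 2 and 3 is secured. Among the measured compounds shown here, the only step beyond the scatter is a 2.6-fold lower number from compound 1 to compound 3 (0.41 log units; beyond the scatter), and that one is modest.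

Compound 4 `O=C(Cc1cccnc1)c1cc2ccc(F)cc2[nH]1` is not yet measured in this assay. It differs from compound 2 in one place: fluoro in place of hydrogen on an aromatic carbon. All three measured steps bear on it insofar as each exchanges a single group on the aromatic core; the exchanges of phenyl for hydrogen or hydroxy, and of hydrogen for hydroxy, moved the numbers little, and the largest of them was only modest. The entering fluoro brings 1 heavy atom, less than any group exchanged among compounds 1, 2 and 3. No step beyond the scatter is therefore expected in this assay. The expected step is a 1.2-fold lower number from compound 2 to compound 4 (0.07 log units; within the scatter). Compound 4 is expected to give 55000 nM in this assay, with a range from 25000 nM to 120000 nM.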

Compound 4, half-maximal inhibitory concentration: 43000 nM
Beside the measured number, compound 4's estimate is 1.3-fold (0.11 log units) above it; low and high end bracket the measured number.
By their numbers in this assay, from the lowest: compounds 3, 4, 2 and 1 (each within the scatter of the next, the first and the last beyond it).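

In this assay, fluoro in place of hydrogen on an aromatic carbon, meta to a fused ring and para to a fused ring, gives a 1.5-fold lower number from compound 2 to compound 4 (0.18 log units; within the scatter) and so adds no secured difference from compound 2. Among the compounds shown here, this carbon is not the one carrying the phenyl of compound 1 or the hydroxy of compound 3, so the result extends the picture to a second carbon of the six-membered aromatic ring: compounds 1, 3 and 4 each stand within the scatter of compound 2 at their one point of change. Nothing measured here accounts for this step, or for the absence of a larger one.

As far as these compounds go, whether an amine, a carboxylic acid, a chlorine or a longer chain on this same carbon would move the number beyond the scatter remains open, as does what fluoro would do on the carbon that carries the phenyl of compound 1. Also open, from the compounds shown here alone, is whether changes outside this ring, at the carbonyl or the chain leading from it, would matter more than any exchange seen so far on the shared core.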